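Series notes: halogen changes on the phenyl ring

This account rests on a few compounds, and the source may have more. Where it says the series, first, only, none or still open, it means among the compounds named here.

Compound 1 `Fc1ccc(-c2csc(N/N=C/c3ccc(-n4ccnc4)cc3)n2)cc1` gives 18.7% in an ADME assay on THP-1 cells (Homo sapiens) for cytotoxicity, read by MTT assay, tested at 50 ug/mL; on this read-out lower numbers stand for less inhibition and higher numbers for more inhibition at the one concentration tested (going by the name of the read-out); compound 2 `Clc1ccc(-c2csc(N/N=C/c3ccc(-n4ccnc4)cc3)n2)cc1` gives 32.1%, and compound 3 `Brc1ccc(-c2csc(N/N=C/c3ccc(-n4ccnc4)cc3)n2)cc1` gives 36.8%, the highest of the three numbers, though its gap to compound 2 is within the scatter. Two steps are beyond the scatter: a number 13.4 percentage points higher from compound 1 to compound 2 (beyond the scatter) and a number 18.1 percentage points higher from compound 1 to compound 3 (beyond the scatter). The halogen swap in a number 4.7 percentage points higher from compound 2 to compound 3 (within the scatter) is within it. Compound 4 `Clc1ccc(-c2csc(N/N=C/c3ccc(-n4ccnc4)cc3)n2)c(Cl)c1` carries the change (2,4-dichlorophenyl in place of 4-bromophenyl on an aromatic carbon). Among the compounds with values here, of the measured steps, the exchange of bromo and chloro bears on it and was small; the second chloro has no measured precedent. For compound 4 the expected step is a number 0.8 percentage points lower from compound 3 to compound 4 (within the scatter), none beyond the scatter. Compound 4 is therefore estimated at 36%, with a range from 22% to 52%.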

Compound 4, a percentage reported as inhibition, at one concentration (the size of the read-out at that concentration, not a potency): 28.8%
Compound 4: middle estimate off by 7.2 percentage points, on the high side; the range from low to high includes it.
By their numbers in this assay, from the lowest: compound 1; then compounds 4, 2 and 3 (each within the scatter of the next).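

The second chloro gives a number 3.3 percentage points lower from compound 2 to compound 4 (within the scatter) and so adds no readable change in this assay at this position on the phenyl ring. Taking 2,4-dichlorophenyl for 4-bromophenyl gives a number 8 percentage points lower from compound 3 to compound 4 (within the scatter) as well, whereas a number 10.1 percentage points higher from compound 1 to compound 4 (beyond the scatter) shows that compound 1 stays apart from the dichloro compound too, as it does from the other two halogen compounds. No measurement shown accounts for these steps.

Open, on these data alone, is whether an amine, a carboxylic acid or a methoxy group on this phenyl ring would shift the number as the halogens do. Also open, as far as these compounds go, is whether a lone chloro at the second site would read like the pair.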